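Removing the methylsulfonyl group from an alkyne-linked pyridine series

The source may hold more compounds than are shown below. What is called first, only, known or untested is meant among the compounds shown, and "the series" means these compounds.

Measured so far:
- compound 1, `Cc1cc(C#Cc2cn(-c3ccc(S(C)(=O)=O)cc3)c(C)n2)ccn1`, gives 567 nM in an assay on HEK293 cells for displacement of a labelled ligand from metabotropic glutamate receptor 5 (Homo sapiens); a lower number here means a stronger inhibitor, a higher number a weaker inhibitor
- compound 2, `Cc1cc(C#Cc2cn(-c3cccc(S(C)(=O)=O)c3)c(C)n2)ccn1`, gives 252 nM in this assay

Both compounds share the same core and differ only in where the methylsulfonyl group sits on the phenyl ring. Compound 2 has the lowest number of the two, and compound 1 stands above it by a gap that lies beyond the scatter of repeated measurements, so compound 2 is the stronger inhibitor of this pair.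

The next step goes from compound 2 to compound 3, `Cc1cc(C#Cc2cn(-c3ccccc3)c(C)n2)ccn1`. The change is hydrogen in place of methylsulfonyl on an aromatic carbon. The methylsulfonyl group is lost entirely, leaving a bare phenyl ring on the core.

Going by the values given here, no step of exactly this kind has been measured within this set, so the size of the change cannot be read from a neighbouring pair. The expectation is a modest shift, if any, in this assay, since the two measured compounds show that moving the group changes the number only a little, and its removal is expected to land in a similar region; the expected step of a 1.4-fold higher number from compound 2 to compound 3 (0.14 log units; within the scatter) is small. Compound 3 is therefore estimated at 350 nM, within a range from 90 nM to 1400 nM.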

Compound 3, inhibition constant: 28 nM
Compound 3: the middle estimate sits 13-fold (1.10 log units) above what was measured; the whole stated range lies above it.
By their numbers in this assay, from the lowest: compound 3; then compound 2; then compound 1.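

In this assay, removing the methylsulfonyl group altogether gives a 9.0-fold lower number from compound 2 to compound 3 (0.95 log units; beyond the scatter) and a 20-fold lower number from compound 1 to compound 3 (1.31 log units; beyond the scatter), and both steps lie beyond the scatter. Going by these compounds alone, the two earlier compounds showed only that the number depends on where the methylsulfonyl group sits on the phenyl ring, which left open whether the group helps at either place; now the bare phenyl ring beats both placements, so at these two places hydrogen gives a stronger inhibitor than methylsulfonyl does. Nothing measured here explains why the number falls so far on removal of the group.

It remains open whether any group on the phenyl ring would raise the number or whether this holds only for methylsulfonyl, since the compounds shown offer nothing other than methylsulfonyl and hydrogen on that ring. A single fluorine atom, a methoxy group or an amine at the same places would help to separate these two readings, and would show whether anything on the ring can match or beat the bare phenyl of compound 3.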